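Swapping Methyl for Ethoxy on a Weak Jurkat Activator

The source may hold more compounds than are shown below. What is called first, only, known or untested is meant among the compounds shown, and "the series" means these compounds.

Of the compounds shown here, three have so far been tested in a functional assay on Jurkat cells (Homo sapiens) for activation, with a stated time of 24 h; on this read-out lower numbers stand for an effect already at smaller amounts and higher numbers for an effect only at larger amounts of compound. Compound 1 `Oc1ccccc1CNc1ccccc1` gives "not active" (no number reported), and compound 2 `CN1CCN(c2ccc(NCc3ccccc3O)cc2)CC1` gives "not active" (no number reported). Compound 3 `Cc1cccc(-c2ccc(NCc3ccccc3O)cc2)c1` gives 9190 nM, which is the only numerical result in this assay; the other two entries carry no number at all. Compound 4 `CCOc1cccc(-c2ccc(NCc3ccccc3O)cc2)c1` differs from compound 3 by ethoxy in place of methyl on an aromatic carbon. Going by the values given here, no pair of measured compounds differs in just one place, so there is no measured step to lean on. Such an exchange is expected to move the result little, if at all beyond the scatter. Compound 4 is therefore estimated at 9000 nM, between 3000 nM and 30000 nM. The expected step is a 1.0-fold lower number from compound 3 to compound 4 (0.01 log units; within the scatter), close to none.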

Compound 4, half-maximal effective concentration: "not active" (no number reported)
No number was reported for compound 4, and the estimate cannot be compared.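

Compound 3 carries a number and compound 4 carries none, so no step can be read between them. Open remains which groups at this place give a measurable effect. Nothing shown here bears on this result.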